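The compounds below may be only part of what the source reports. "The series", "measured", "known", "first", "only" and "open" are said of these compounds alone.

Compound 1 `O=C(Nc1cccc(-n2cc(-c3ccncc3)c(-c3ccc(Cl)c(O)c3)n2)c1)Nc1cccc(C(F)(F)F)c1` carries a 3-(trifluoromethyl)phenyl group on an amide-type nitrogen. In a functional assay on MDA-MB-435 cells (Homo sapiens) for inhibition, read by sulforhodamine B assay, with a stated time of 48 h (on this read-out lower numbers stand for stronger inhibition of growth and higher numbers for weaker inhibition of growth), compound 1 gives 1490 nM. Compound 2 `O=C(Nc1cccc(-n2cc(-c3ccncc3)c(-c3ccc(Cl)c(O)c3)n2)c1)Nc1ccc(Cl)c(Cl)c1` gives 1100 nM and compound 3 `COc1cc(-c2nn(-c3cccc(NC(=O)Nc4cccc(C(F)(F)F)c4)c3)cc2-c2ccncc2)ccc1Cl` gives 866 nM, so the number for compound 1 is the highest of the three, yet both gaps stay within the scatter: a 1.4-fold lower number from compound 1 to compound 2 (0.13 log units; within the scatter) and a 1.7-fold lower number from compound 1 to compound 3 (0.24 log units; within the scatter). Compound 4 `O=C(Nc1cccc(-n2cc(-c3ccncc3)c(-c3ccc(Cl)c(O)c3)n2)c1)Nc1cc(C(F)(F)F)cc(C(F)(F)F)c1` differs from compound 1 by trifluoromethyl in place of hydrogen on an aromatic carbon. The step from compound 1 to compound 2 swapped the whole group on that same ring and moved nothing beyond the scatter; the step to compound 3 touched another part of the molecule. A second trifluoromethyl on that ring is therefore expected to leave the number essentially unchanged, a 1.1-fold lower number from compound 1 to compound 4 (0.06 log units; within the scatter). Compound 4 is thus estimated at 1300 nM, between 500 nM and 3500 nM.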

Compound 4, concentration for 50% growth inhibition: 910 nM
For compound 4 the middle estimate is 1.4-fold (0.15 log units) above the measured one; the range from low to high includes it.
By their numbers in this assay, from the lowest: compounds 3, 4, 2 and 1 (each within the scatter of the next).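

In this assay, the aromatic carbon meta to the trifluoromethyl group of compound 1 takes a second trifluoromethyl, adding 4 heavy atoms, with only a 1.6-fold lower number from compound 1 to compound 4 (0.21 log units; within the scatter). Unlike the swap of the whole group in compound 2, this change adds to the ring and keeps the original trifluoromethyl, and the number still does not move beyond the scatter. No available evidence bears on why the number stays within the scatter. Going by these compounds, whether an amine or a carboxylic acid on this same carbon would shift the number beyond the scatter remains open.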